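The source may hold more compounds than are shown below. What is called first, only, known or untested is meant among the compounds shown, and "the series" means these compounds.

Of the compounds shown here, three built on a shared core have been measured in a functional assay on HeLa cells (Homo sapiens) for antiproliferative activity, read by MTT assay, with a stated time of 48 h; a higher number here means a weaker inhibitor, a lower number a stronger inhibitor. Compound 1 `CCn1cc(-c2nc3ccc([N+](=O)[O-])cc3o2)c(=O)c2cc(F)c(N3CCNC(C)C3)c(F)c21` gives 2980 nM, compound 2 `CCn1cc(-c2ccc(F)cc2)c(=O)c2cc(F)c(N3CCNCC3)cc21` gives 60900 nM, and compound 3 `CCn1cc(-c2ccc(Cl)cc2)c(=O)c2cc(F)c(N3CCNCC3)cc21` gives 15400 nM. Compound 2 thus stands with the highest number of the three: the step of a 4.0-fold lower number from compound 2 to compound 3 (0.60 log units; beyond the scatter) separates it from its nearest neighbour, and the gap to compound 1 is wider still. Compound 4 `CCn1cc(-c2ccc(C#N)cc2)c(=O)c2cc(F)c(N3CCNCC3)cc21` has not yet been measured. It differs from compound 2 as follows: cyano in place of fluoro on an aromatic carbon. Among the compounds with values here, only one measured step touches the same spot, a 4.0-fold lower number from compound 2 to compound 3 (0.60 log units; beyond the scatter), where chloro took the place of the same fluoro on an aromatic carbon. Within the data shown here, a different group entering at that spot therefore makes a step toward a lower number in this assay plausible, though its size is uncertain, as no cyano analogue has been measured here. Compound 4 is expected to give about 20000 nM, within a range of 6000 nM to 60000 nM. That expectation means a step of a 3.0-fold lower number from compound 2 to compound 4 (0.48 log units; beyond the scatter).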

Compound 4, half-maximal inhibitory concentration: 14600 nM
Compound 4: middle estimate off by 1.4-fold (0.14 log units), on the high side; low and high end bracket the measured number.
By their numbers in this assay, from the lowest: compound 1; then compounds 4 and 3 (each within the scatter of the next); then compound 2.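

In this assay the step of a 4.2-fold lower number from compound 2 to compound 4 (0.62 log units; beyond the scatter) shows that the gain seen with chloro at this spot is not particular to chloro: a second, different group replacing fluoro also moves the number beyond the scatter. The step of a 1.1-fold lower number from compound 3 to compound 4 (0.02 log units; within the scatter) leaves chloro and cyano indistinguishable here, so among the three groups tried on this core, it is the fluoro of compound 2 that stands apart. No measurement at hand explains this difference.

As far as these compounds go, whether a methoxy group, an amine or a carboxylic acid at the same spot would join chloro and cyano, pass them or fall back towards fluoro remains open. So does whether the same replacements would have a similar effect with other groups elsewhere on the shared core.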